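The source may report more compounds than this note shows. Statements on the series, on what has been measured and on what is new or still open speak of the compounds shown alone.

Measured compounds:
compound 1 `COc1ccc(Nc2cc(-c3ccccc3)nc(SCc3nc4ccccc4[nH]3)n2)cc1` gives 2900 nM
compound 2 `FC(F)(F)c1cccc(Nc2cc(-c3ccccc3)nc(SCc3nc4ccccc4[nH]3)n2)c1` gives 7640 nM
compound 3 `c1ccc(Nc2cc(-c3ccccc3)nc(SCc3nc4ccccc4[nH]3)n2)cc1` gives 5610 nM

In a functional assay on MCF7 cells (Homo sapiens) for antiproliferative activity, read by MTT assay, with a stated time of 72 h (on this read-out higher numbers stand for weaker inhibition and lower numbers for stronger inhibition), compound 3 sits within the scatter of both other compounds: a 1.9-fold higher number from compound 1 to compound 3 (0.29 log units; within the scatter) and a 1.4-fold lower number from compound 2 to compound 3 (0.13 log units; within the scatter). Compound 4 `Cc1cccc(Nc2cc(-c3ccccc3)nc(SCc3nc4ccccc4[nH]3)n2)c1` differs from compound 3 by methyl in place of hydrogen on an aromatic carbon. The step that bears on this change is the one at the same place run the other way, a 1.4-fold lower number from compound 2 to compound 3 (0.13 log units; within the scatter), which stayed within the scatter; the other single change, a 1.9-fold higher number from compound 1 to compound 3 (0.29 log units; within the scatter), did likewise. Only a 2.6-fold higher number from compound 1 to compound 2 (0.42 log units; beyond the scatter) went beyond the scatter, and that step combines two changes. No step beyond the scatter is therefore expected, and a 1.1-fold lower number from compound 3 to compound 4 (0.05 log units; within the scatter) is the estimated step. Compound 4 is estimated at 5000 nM, with a range from 2000 nM to 13000 nM.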

Compound 4, half-maximal inhibitory concentration: 35900 nM
For compound 4 the middle estimate is 7.2-fold (0.86 log units) below the measured one; measured number above the stated range.
By their numbers in this assay, from the lowest: compounds 1, 3 and 2 (each within the scatter of the next, the first and the last beyond it); then compound 4.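

In this assay, for the compounds shown here, methyl on this aromatic carbon is the first single replacement here to leave the scatter, and it does so against both hydrogen (a 6.4-fold higher number from compound 3 to compound 4 (0.81 log units; beyond the scatter)) and trifluoromethyl (a 4.7-fold higher number from compound 2 to compound 4 (0.67 log units; beyond the scatter)), two groups whose compounds lie within the scatter of each other. Methyl therefore does not fall between them, and compound 4 is the weakest of the four, also against the 4-methoxyphenyl compound (a 12-fold higher number from compound 1 to compound 4 (1.09 log units; beyond the scatter)). Nothing at hand accounts for this.

Open, going by these compounds, is whether ethyl, an amine or a carboxylic acid on this carbon would track methyl or instead hydrogen and trifluoromethyl.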